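Replacing the Hydroxypiperidine Amide: Expectation for Compound 3

The compounds below may be only part of what the source reports. "The series", "measured", "known", "first", "only" and "open" are said of these compounds alone.

Measured compounds:
compound 1, `CC(C)(C)OC(=O)NCCNC(=O)CN1CN(c2ccccc2)C2(CCN(C(=O)c3ccc(C(C)(C)C)cc3)CC2)C1=O`, gives 10900 nM in an assay on HEK293 cells for displacement of a labelled ligand from NPC1-like intracellular cholesterol transporter 1 (Homo sapiens); a higher number here means a weaker inhibitor, a lower number a stronger inhibitor.
compound 2, `CC(C)(C)c1ccc(C(=O)N2CCC3(CC2)C(=O)N(CC(=O)N2CCC(O)CC2)CN3c2ccccc2)cc1`, gives 4700 nM in this assay.

Among the measured compounds shown here, compound 2 holds the lower of the two numbers; the only measured step, a 2.3-fold lower number from compound 1 to compound 2 (0.37 log units; beyond the scatter), is modest and beyond the scatter. Compound 3, `CCC1CCCN(C(=O)CN2CN(c3ccccc3)C3(CCN(C(=O)c4ccc(C(C)(C)C)cc4)CC3)C2=O)C1`, differs from compound 2 by 3-ethylpiperidin-1-yl in place of 4-hydroxypiperidin-1-yl on a carbonyl carbon. For the measured compounds named here, no measured step involves this change; the one step known concerns a different group on a carbonyl carbon and says nothing about ethyl in place of hydroxy. A step within the scatter, or a modest one in either direction, is therefore expected: a 1.6-fold lower number from compound 2 to compound 3 (0.19 log units; within the scatter). Compound 3 is estimated at 3000 nM, within 1000 nM to 12000 nM.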

Compound 3, half-maximal inhibitory concentration: 3900 nM
The estimate for compound 3 lay 1.3-fold (0.11 log units) below the measured number; measured number inside the range.
By their numbers in this assay, from the lowest: compounds 3 and 2 (each within the scatter of the next); then compound 1.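

In this assay, 3-ethylpiperidin-1-yl in place of 4-hydroxypiperidin-1-yl on this carbonyl carbon gives a 1.2-fold lower number from compound 2 to compound 3 (0.08 log units; within the scatter) and so stays within the scatter, even though the hydrogen-bond donor and acceptor of the leaving group are gone. Against the open chain of compound 1, the new piperidine amide gives a 2.8-fold lower number from compound 1 to compound 3 (0.45 log units; beyond the scatter) and so joins compound 2 on the lower side of compound 1. Nothing available explains these numbers. Still open, as far as these compounds go, is whether an amine or a carboxylic acid on the piperidine ring would move the number beyond the scatter.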